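Removing the fluoro from compound 2: expected outcome

The source may hold more compounds than are shown below. What is called first, only, known or untested is meant among the compounds shown, and "the series" means these compounds.

The series shares one core with an amide-linked chain. Compound 2 `O=C(NCCCCc1ccccc1)c1cc(F)cc(C2SCC(=O)N2c2ccccn2)c1` stands lowest of the two numbers in a functional assay on HOS-TE85 cells (Homo sapiens) for inhibition, read by CCK-8 assay, with a stated time of 72 h (on this read-out lower numbers stand for stronger inhibition and higher numbers for weaker inhibition), giving 14.2 nM. Compound 3 `COc1ccccc1N1C(=O)CSC1c1cc(F)cc(C(=O)NCCCCc2ccccc2)c1` gives 40.9 nM in this assay; the step of a 2.9-fold higher number from compound 2 to compound 3 (0.46 log units; beyond the scatter) comes from 2-methoxyphenyl in place of pyridin-2-yl on an amide-type nitrogen in a ring. Compound 1 `COc1ccccc1N1C(=O)CSC1c1cccc(C(=O)NCCCCn2cncn2)c1` reaches only a limit, > 1000 nM in this assay, which is not a number. Compound 4 `O=C(NCCCCc1ccccc1)c1cccc(C2SCC(=O)N2c2ccccn2)c1` is not yet measured; it differs from compound 2 by hydrogen in place of fluoro on an aromatic carbon. Within the data shown here, no measured step removes a fluoro, so nothing measured bears directly on this change, and the expected step of a 1.5-fold higher number from compound 2 to compound 4 (0.19 log units; within the scatter) is small, within the scatter. Compound 4 is estimated at 22 nM, with a range from 8 nM to 60 nM in this assay.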

Compound 4, half-maximal inhibitory concentration: 19.7 nM
Compound 4: the middle estimate sits 1.1-fold (0.05 log units) above what was measured; low and high end bracket the measured number.
By their numbers in this assay, from the lowest: compounds 2 and 4 (each within the scatter of the next); then compound 3. At a limit, above all of these: compound 1.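

In this assay, hydrogen in place of fluoro on this aromatic carbon, meta to two large groups, gives a 1.4-fold higher number from compound 2 to compound 4 (0.14 log units; within the scatter), so the fluoro is not required here. Among these compounds, this is the first read on this position, as the earlier step changed only the group on the amide-type nitrogen in a ring. Nothing at hand gives a cause for this step. Open, going by these compounds, is whether a chloro, methoxy or nitrile on the same carbon would shift the number. Also open, on these data alone, is whether hydrogen in place of fluoro behaves alike with the 2-methoxyphenyl group of compound 3.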